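The source may report more compounds than this note shows. Statements on the series, on what has been measured and on what is new or still open speak of the compounds shown alone.

Among the three measured compounds, compound 3 `CC(C)Cc1cnc(C(=O)/C=C/c2ccccc2O)cn1` gives the lowest number in a functional assay on the whole organism for inhibition, with Chlorella vulgaris as the target, read by spectrophotometry, with a stated time of 4 h (on this read-out lower numbers stand for stronger inhibition and higher numbers for weaker inhibition), namely 63000 nM. Compound 1 `CC(C)c1cnc(C(=O)/C=C/c2ccccc2O)cn1` gives 78000 nM in this assay, and compound 2 `CCCCc1cnc(C(=O)/C=C/c2ccccc2O)cn1` gives 147000 nM. Compound 4 `CCCc1cnc(C(=O)/C=C/c2ccccc2O)cn1` differs from compound 3 by hydrogen in place of methyl on a saturated chain carbon bound to two saturated chain carbons, which read one bond further out is isobutyl to propyl. Going by the values given here, two measured steps bear on this change: a 2.3-fold lower number from compound 2 to compound 3 (0.37 log units; beyond the scatter), and a 1.9-fold higher number from compound 1 to compound 2 (0.28 log units; within the scatter). Compound 4 carries propyl where compound 2 carries butyl and compound 3 carries isobutyl, so in this assay a step no larger than the scatter, if anything toward a higher number, is expected. On that basis compound 4 is estimated to give 90000 nM, with a range from 45000 nM to 180000 nM. That estimate amounts to an expected step of a 1.4-fold higher number from compound 3 to compound 4 (0.15 log units; within the scatter).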

Compound 4, half-maximal inhibitory concentration: 100000 nM
Compound 4: middle estimate off by 1.1-fold (0.05 log units), on the low side, within the range that was stated.
By their numbers in this assay, from the lowest: compounds 3, 1, 4 and 2 (each within the scatter of the next, the first and the last beyond it).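

In this assay, hydrogen in place of methyl on a saturated chain carbon, which turns isobutyl into propyl, gives a step within the scatter (a 1.6-fold higher number from compound 3 to compound 4 (0.20 log units; within the scatter)), and the same change on butyl also stays within it (a 1.5-fold lower number from compound 2 to compound 4 (0.17 log units; within the scatter)). Propyl in place of isopropyl likewise stays within the scatter (a 1.3-fold higher number from compound 1 to compound 4 (0.11 log units; within the scatter)), so propyl is not separated from any of the other three chains, and only butyl and isobutyl remain apart. No measurement offered here accounts for these steps. The compounds shown leave open what an amine, a carboxylic acid or a chain longer than butyl on that aromatic carbon would give.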